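The source may report more compounds than this note shows. Statements on the series, on what has been measured and on what is new or still open speak of the compounds shown alone.

Compound 1: `C=CCOC(=O)SCCCCCCNC(=O)c1cc(-c2ccncc2)n[nH]1` — in an ADME assay on HEK293 cells (Homo sapiens) for inhibition, read by MTT assay, with a stated time of 96 h (on this read-out lower numbers stand for stronger inhibition of growth and higher numbers for weaker inhibition of growth), compound 1 gives 27500 nM.
Compound 2: `CCCC(=O)SCCCCCCNC(=O)c1cc(-c2ccncc2)n[nH]1` — here compound 2 gives > 50000 nM, which is a limit of this assay and not a number.
Compound 3: `CSCCCCCCNC(=O)c1cc(-c2ccncc2)n[nH]1` — here compound 3 gives > 50000 nM, again a limit rather than a number.

Compound 3 therefore stands at the limit of this assay, where two of the three shown values sit, as the limit of > 50000 nM in this assay, at which 2 of the 3 values shown sit, records. The measured steps give little to work with: the step of an at least 1.8-fold higher number from compound 1 to compound 3 (0.25 log units; that floor lies within the scatter) has a floor that lies within the scatter, and the step that the two limits leave unreadable from compound 2 to compound 3 cannot be read at all because both ends are limits.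

Compound 4, `CCC(=O)SCCCCCCNC(=O)c1cc(-c2ccncc2)n[nH]1`, has not yet been measured. It differs from compound 3 by propanoyl in place of methyl on a sulfur. The closest measured neighbour to this change is compound 2, whose thioester value is itself a limit of this assay. With compound 3 at a limit and compound 2 at the same limit, no step beyond the scatter can be expected in this assay in either direction; the step that the limit leaves unreadable from compound 3 to compound 4 is estimated as flat. Compound 4 is expected at 60000 nM, within a range from 30000 nM to 150000 nM, and most probably reported as a limit again.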

Compound 4, concentration for 50% growth inhibition: > 50000 nM
Compound 4 ended at the assay's limit; the forecaster's own chance of this, stated with the estimate: 75%; the middle value does not contradict the limit.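

In this assay compound 4 gives > 50000 nM, which is a limit of the assay and not a number. Propanoyl in place of methyl on the sulfur thus yields no value that can be told apart from that of compound 3, the shorter acyl group of compound 4 ends where the butanoyl thioester compound 2 ended, and the steps among these three compounds cannot be read: the limit of > 50000 nM in this assay, at which 3 of the 4 values shown sit. Ethyl in place of allyloxy on the carbonyl carbon gives an at least 1.8-fold higher number from compound 1 to compound 4 (0.25 log units; that floor lies within the scatter), so this change does not separate the two compounds beyond the scatter, and the only number in the series remains that of compound 1, at 27500 nM.

On these data alone, whether compound 2, compound 3 and compound 4 differ from one another at all remains open, as their true values lie beyond the reach of the limit. Also open, as far as these compounds go, is how a free thiol, an amine or a longer acyl chain on the sulfur would read in this assay.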